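Benzyl for Cyclohexyl on a Second Linker Scaffold

The compounds below may be only part of what the source reports. "The series", "measured", "known", "first", "only" and "open" are said of these compounds alone.

Three compounds have been measured in an assay on HeLa cells for displacement of a labelled ligand from adenosine receptor A3 (Homo sapiens), read by fluorescence polarization, with a stated time of 30 min; a lower number here means a stronger inhibitor, a higher number a weaker inhibitor:

Compound 1, `COc1ccc(-c2cc(NC(=O)CCC(=O)N(C)CC(=O)NC3CCCCC3)nc(-c3ccc(OC)cc3)n2)cc1`, gives 18500 nM.
Compound 2, `COc1ccc(-c2cc(NC(=O)CCC(=O)N(C)CC(=O)NCc3ccccc3)nc(-c3ccc(OC)cc3)n2)cc1`, gives 9500 nM.
Compound 3, `COc1ccc(-c2cc(NC(=O)COCC(=O)N3CCN(CC(=O)NC4CCCCC4)CC3)nc(-c3ccc(OC)cc3)n2)cc1`, gives 18300 nM.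

All three share the same pair of methoxyphenyl-bearing heterocyclic cores and differ in the chain that ends in an amide. Compound 1 and compound 2 differ only by benzyl in place of cyclohexyl on an amide-type nitrogen, and this gave a 1.9-fold lower number from compound 1 to compound 2 (0.29 log units; within the scatter). Compound 3 carries a different chain; how its core differs from that of compound 1 is not broken down here, and the two values of compound 3 and compound 1 sit essentially together.

Compound 4, `COc1ccc(-c2cc(NC(=O)COCC(=O)N3CCN(CC(=O)NCc4ccccc4)CC3)nc(-c3ccc(OC)cc3)n2)cc1`, is not yet measured. It stands to compound 3 as compound 2 stands to compound 1: benzyl in place of cyclohexyl on an amide-type nitrogen. Since the place is described in the same words in both cases, this is the same change. Because the earlier step was a 1.9-fold lower number from compound 1 to compound 2 (0.29 log units; within the scatter), the step from compound 3 to compound 4 is expected to be of similar size, a 1.7-fold lower number from compound 3 to compound 4 (0.22 log units; within the scatter), resting on a single precedent only. Compound 4 is therefore estimated at 11000 nM, between 5000 nM and 25000 nM.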

Compound 4, inhibition constant: 9300 nM
Beside the measured number, compound 4's estimate is 1.2-fold (0.07 log units) above it, within the range that was stated.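

In this assay, benzyl in place of cyclohexyl on an amide-type nitrogen gave a 2.0-fold lower number from compound 3 to compound 4 (0.29 log units; within the scatter). Set beside the earlier case, the change reads alike on both cores: the same change on two cores in this assay, a 1.9-fold lower number (0.29 log units; within the scatter) from compound 1 to compound 2 and a 2.0-fold lower number (0.29 log units; within the scatter) from compound 3 to compound 4, 1.0-fold (0.00 log units) apart, within the scatter of two such steps. In these two pairs, then, the step carried from one core to the other with no visible difference in size, but each step alone lies within the scatter, so the pairs do not show that the change has a real effect on the number, and two cores say nothing firm about any other core in the series.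

As far as these compounds go, only cyclohexyl and benzyl appear at this end of the chain, so it remains open whether phenyl, a longer chain such as phenethyl, or a benzyl ring carrying an amine or a carboxylic acid would move the number beyond the scatter. From the compounds shown here alone, it is also open whether the same step would hold if the two methoxy groups were replaced, for example by hydroxyl or chlorine.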